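Methoxy in Place of Methyl on the Shared Core

The source may hold more compounds than are shown below. What is called first, only, known or untested is meant among the compounds shown, and "the series" means these compounds.

Compound 1, `Cc1ccc2ncc(S(=O)(=O)c3cc(Cl)cc(Cl)c3)c(N3CCC(C)CC3)c2c1`, was tested in an assay on isolated protein for displacement of a labelled ligand from metabotropic glutamate receptor 5 (Homo sapiens), with a stated time of 60 min, tested at 1 uM (on this read-out lower numbers stand for less inhibition and higher numbers for more inhibition at the one concentration tested (going by the name of the read-out)), and gave 75%, the highest of the two numbers measured, with compound 2 as its nearest neighbour. Compound 2, `Cc1ccc2ncc(S(=O)(=O)c3ccccc3)c(N3CCC(C)CC3)c2c1`, gives 67% in this assay. Among the compounds with values here, the one measured step, a number 8 percentage points lower from compound 1 to compound 2 (within the scatter), changes the aryl on the sulfonyl sulfur and leaves the shared core untouched.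

Compound 3, `COc1ccc2ncc(S(=O)(=O)c3cc(Cl)cc(Cl)c3)c(N3CCC(C)CC3)c2c1`, differs from compound 1 in another place: methoxy in place of methyl on an aromatic carbon. Within the data shown here, no measured step touches this part of the shared core, so nothing in the data speaks directly to the exchange. Among the measured compounds shown here, the only guidance is indirect: the change at the sulfonyl sulfur moved the number by an amount that stayed within the scatter, and the exchange of methyl for methoxy is a small change in what is counted. The expected step is therefore a number 5 percentage points lower from compound 1 to compound 3 (within the scatter), none beyond the scatter in either direction. Compound 3 is estimated at 70% in this assay, with a range from 50% to 88%.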

Compound 3, a percentage reported as inhibition, at one concentration (the size of the read-out at that concentration, not a potency): 87%
For compound 3 the middle estimate is 17 percentage points below the measured one, and the stated range covers the measured number.
By their numbers in this assay, from the lowest: compounds 2 and 1 (each within the scatter of the next); then compound 3.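

In this assay, within the data shown here, the exchange of methyl for methoxy on an aromatic carbon gives a number 12 percentage points higher from compound 1 to compound 3 (beyond the scatter) and so shows that this part of the shared core, which no earlier step touched, can move the number beyond the scatter. The only earlier step, a number 8 percentage points lower from compound 1 to compound 2 (within the scatter) at the sulfonyl sulfur, stayed within the scatter, which leaves the methoxy exchange as the one step shown that goes beyond it, though it is modest and rests on a single pair with 3,5-dichlorophenyl on the sulfonyl sulfur. The entering group brings one more heavy atom and one hydrogen-bond acceptor, but no measurement presented here accounts for the higher number.

The compounds shown leave open whether methoxy in place of methyl would raise the number in the same way with phenyl on the sulfonyl sulfur, so the two changes cannot yet be read together. They also leave open what a longer chain such as ethoxy, a hydroxyl or an amine would give on the same aromatic carbon, and so whether the oxygen of methoxy or merely a larger group goes with the rise.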